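Trifluoromethoxy for trifluoromethyl on the aryl ring of compound 1

The source may hold more compounds than are shown below. What is called first, only, known or untested is meant among the compounds shown, and "the series" means these compounds.

compound 1 `COc1ccc2cc(C(C)c3nnc4n3N=C(c3ccc(C(F)(F)F)cc3)CS4)ccc2c1` — 14800 nM
compound 2 `CC(C)Cc1ccc(C(C)c2nnc3n2N=C(c2ccc(Br)cc2)CS3)cc1` — 4900 nM
compound 3 `CC(c1ccc(-c2ccccc2)c(F)c1)c1nnc2n1N=C(c1ccc(Br)cc1)CS2` — 5000 nM

In a functional assay on Huh-7 cells (Homo sapiens) for inhibition, read by sulforhodamine B assay, with a stated time of 72 h (on this read-out lower numbers stand for stronger inhibition and higher numbers for weaker inhibition), compound 1 gives 14800 nM, the highest of the three numbers. Compound 3 gives 5000 nM, lower by more than the scatter. Compound 2 gives 4900 nM, also lower by more than the scatter. The two lower compounds lie close to each other.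

Compound 4 `COc1ccc2cc(C(C)c3nnc4n3N=C(c3ccc(OC(F)(F)F)cc3)CS4)ccc2c1` differs from compound 1 in one place: trifluoromethoxy in place of trifluoromethyl on an aromatic carbon. For the measured compounds named here, no measured pair shows this change, so there is no step to lean on. The step of a 1.2-fold lower number from compound 1 to compound 4 (0.09 log units; within the scatter) is expected to be small, with no clear direction and not beyond the scatter. Compound 4 is therefore expected to give about 12000 nM, between 5000 nM and 30000 nM.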

Compound 4, half-maximal inhibitory concentration: 16000 nM
Compound 4: the middle estimate sits 1.3-fold (0.12 log units) below what was measured; measured number inside the range.
By their numbers in this assay, from the lowest: compounds 2 and 3 (each within the scatter of the next); then compounds 1 and 4 (each within the scatter of the next).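

In this assay, for the compounds shown here, the step of a 1.1-fold higher number from compound 1 to compound 4 (0.03 log units; within the scatter) is the first matched pair at this position, para to a large group. Trifluoromethoxy and trifluoromethyl cannot be told apart there on the core of compound 1, so this change gives no handle on the read-out. No measurement at hand bears on why.

Open, from the compounds shown here alone, is whether a group of another kind in this place, such as an amine or a carboxylic acid, would move the number beyond the scatter. Also open, going by these compounds, is how bromine, carried by compound 2 and compound 3, would compare on the core of compound 1.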